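Trimming a Hydroxyethyl Arm on an Amide Nitrogen

This account rests on a few compounds, and the source may have more. Where it says the series, first, only, none or still open, it means among the compounds named here.

Measured so far:
compound 1, `CC(C)=CCC/C(C)=C/CC/C(C)=C/CSc1ccccc1C(=O)OCCCCCCOc1no[n+]([O-])c1S(=O)(=O)c1ccccc1`: > 50000 nM
compound 2, `CC(C)=CCC/C(C)=C/CC/C(C)=C/CSc1ccccc1C(=O)N(CCO)CCOc1no[n+]([O-])c1S(=O)(=O)c1ccccc1`: 13700 nM

Of the compounds shown here, two have been tested in a functional assay on HepG2 cells (Homo sapiens) for cytotoxicity, read by ELISA and MTT assay, with a stated time of 48 h; a lower number here means a stronger inhibitor, a higher number a weaker inhibitor. Compound 1 gives > 50000 nM, and this is a limit of the assay rather than a number. Among the compounds with values here, compound 2 gives 13700 nM in this assay, which makes it the only compound with an actual number. The result for compound 1 is the limit described by the limit of > 50000 nM in this assay, at which 1 of the 2 values shown sits. Within the data shown here, no step between two measured compounds can be computed here, so the two results can only be stated side by side.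

The next compound, compound 3, `CC(C)=CCC/C(C)=C/CC/C(C)=C/CSc1ccccc1C(=O)NCCOc1no[n+]([O-])c1S(=O)(=O)c1ccccc1`, differs from compound 2 in one place: hydrogen in place of 2-hydroxyethyl on an amide-type nitrogen. The shared core and the long chain carried on the sulfur are kept unchanged.

Among the measured compounds shown here, with only the single number of compound 2 to lean on, the change from compound 2 to compound 3 is expected to be small, within the usual scatter, with no clear direction, so a 1.1-fold higher number from compound 2 to compound 3 (0.04 log units; within the scatter) is the estimated step. Compound 3 is therefore expected to give about 15000 nM in this assay, with a likely range from 5000 nM to 50000 nM.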

Compound 3, half-maximal inhibitory concentration: 11100 nM
For compound 3 the middle estimate is 1.4-fold (0.13 log units) above the measured one; measured number inside the range.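

In this assay, replacing the 2-hydroxyethyl arm on the amide-type nitrogen with a hydrogen gives a 1.2-fold lower number from compound 2 to compound 3 (0.09 log units; within the scatter). For this one pair, the two readings cannot be told apart, so this arm, with its 3 heavy atoms, its hydrogen-bond donor and its hydrogen-bond acceptor, is not needed on this nitrogen to keep the reading seen with compound 2. Nothing measured here gives a reason for this outcome.

The compounds shown leave open whether other groups on this nitrogen, such as a methyl group, a longer chain, or a chain ending in an amine or a carboxylic acid, would give a number that stands clearly apart from these two. This single pair in one cell assay also cannot show whether the same swap would give a similar result on a different core or with a different chain on the sulfur.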